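Stretching the amide substituent from phenyl to phenethyl

The source may hold more compounds than are shown below. What is called first, only, known or untested is meant among the compounds shown, and "the series" means these compounds.

Of the compounds shown here, two on one shared core have been tested in an assay on isolated protein for inhibition of Nitric oxide synthase, inducible (Homo sapiens), with a stated time of 30 min, tested at 1 mM; a higher number here means more inhibition at the concentration tested (going by the name of the read-out), a lower number less inhibition. Compound 1 `COc1cc(N)c(C2=NN(C(=O)C3CC3)CC2)cc1OC` gives 25.2%. Compound 2 `COc1cc(N)c(C2=NN(C(=O)c3ccccc3)CC2)cc1OC` gives 28.9%. Among the measured compounds shown here, on these two numbers compound 2 stands level with compound 1, since the only measured step, a number 3.7 percentage points higher from compound 1 to compound 2 (within the scatter), is within the scatter and the two values cannot be told apart.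

Compound 3 `COc1cc(N)c(C2=NN(C(=O)CCc3ccccc3)CC2)cc1OC` has not been measured yet. It differs from compound 2 in one place: phenethyl in place of phenyl on a carbonyl carbon. For the measured compounds named here, the one measured step bears directly on this position, because a number 3.7 percentage points higher from compound 1 to compound 2 (within the scatter) shows that exchanging cyclopropyl for phenyl on the same carbonyl carbon produced no change beyond the scatter. The new group keeps the same aromatic ring and joins it to the carbonyl carbon through a longer chain, so there is no sign in the measured numbers that this spot steers the read-out.

For compound 3 the expected step is therefore a number 0.9 percentage points lower from compound 2 to compound 3 (within the scatter), none beyond the scatter. Compound 3 is estimated at 28%, between 12% and 45%.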

Compound 3, a percentage reported as inhibition, at one concentration (the size of the read-out at that concentration, not a potency): 23.7%
Estimate against measurement, compound 3: 4.3 percentage points above, and the stated range covers the measured number.
By their numbers in this assay, from the lowest: compounds 3, 1 and 2 (each within the scatter of the next).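

With compound 3, three different groups have now stood on this carbonyl carbon, and in this assay no exchange among them moves the read-out beyond the scatter. The earlier pair showed only that phenyl could replace cyclopropyl; the new comparisons add that phenethyl, which carries the same aromatic ring on a longer link, also makes no measurable difference, with a number 5.2 percentage points lower from compound 2 to compound 3 (within the scatter) and a number 1.5 percentage points lower from compound 1 to compound 3 (within the scatter). Over these three groups, then, neither the presence of an aromatic ring nor the added length of the link separates the compounds, and the three values cannot be told apart in this assay.

Nothing available here explains why these groups read alike. As far as these compounds go, it remains open whether a group of another kind on this carbonyl carbon, such as an amine, a carboxylic acid or a phenyl ring on a still longer chain, would lift the inhibition clearly beyond the scatter or lower it, or whether this position has little influence on the read-out whatever group it carries.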